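Swapping the Ring at the End of the Chain

The compounds below may be only part of what the source reports. "The series", "measured", "known", "first", "only" and "open" are said of these compounds alone.

Two close relatives of one shared core have been tested in a functional assay on K562 cells (Homo sapiens) for cytotoxicity, read by MTT assay and WST assay, with a stated time of 72 h; a higher number here means a weaker inhibitor, a lower number a stronger inhibitor. Compound 1 `CCN(CC)CCCOc1cc2ncnc(Nc3ccc4sc(C(=O)Nc5c(C)cccc5Cl)cc4c3)c2cc1OC` gives 3550 nM. Compound 2 `COc1cc2c(Nc3ccc4sc(C(=O)Nc5c(C)cccc5Cl)cc4c3)ncnc2cc1OCCCN1CCCCC1` gives 4010 nM. Among the measured compounds shown here, on these two numbers compound 2 stands alongside compound 1 rather than apart from it: the only measured step, a 1.1-fold higher number from compound 1 to compound 2 (0.05 log units; within the scatter), stays inside the scatter, so the two cannot be told apart here.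

Compound 3 `COc1cc2c(Nc3ccc4sc(C(=O)Nc5c(C)cccc5Cl)cc4c3)ncnc2cc1OCCCN1CCN(C)CC1` is still to be measured. It differs from compound 2 in a single place: 4-methylpiperazin-1-yl in place of piperidin-1-yl on a saturated chain carbon, three bonds along the chain from an oxygen on an aromatic ring. For the measured compounds named here, only one measured step speaks to this change, and it is a close guide because a 1.1-fold higher number from compound 1 to compound 2 (0.05 log units; within the scatter) also exchanged the nitrogen-bearing group at the end of that same chain and produced nothing beyond the scatter. The step from compound 2 to compound 3 is therefore expected to be small, a 1.0-fold lower number from compound 2 to compound 3 (0.00 log units; within the scatter), with no clear direction. Compound 3 is estimated to give 4000 nM in this assay, with a likely range from 1500 nM to 10000 nM.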

Compound 3, half-maximal inhibitory concentration: 9880 nM
Compound 3: the middle estimate sits 2.5-fold (0.39 log units) below what was measured; measured number inside the range.
By their numbers in this assay, from the lowest: compounds 1 and 2 (each within the scatter of the next); then compound 3.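

In this assay, the group at the end of this chain turns out not to be freely exchangeable: 4-methylpiperazin-1-yl gives a 2.5-fold higher number from compound 2 to compound 3 (0.39 log units; beyond the scatter) and also a 2.8-fold higher number from compound 1 to compound 3 (0.44 log units; beyond the scatter) while the earlier swap of diethylamino for piperidin-1-yl stayed within the scatter. Both new steps are modest, yet they point the same way, so among these three compounds the one group with 2 hetero atoms in its ring stands apart from the other two, and a single exchange at this position no longer serves as a guide to every other exchange there. Nothing available explains why the number rises with this group, and neither the added ring nitrogen nor the added methyl can be singled out as responsible.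

The compounds shown leave open which part of the new group carries the shift, a question that piperazin-1-yl without the methyl, or morpholin-4-yl with a ring oxygen in place of the second nitrogen, would address. They also leave open whether the same gap between these groups holds on a shorter chain, such as 2-(4-methylpiperazin-1-yl)ethyl against 2-(piperidin-1-yl)ethyl.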